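Trimming One Hydroxy Group from a Stilbene Sulfonamide

This account rests on a few compounds, and the source may have more. Where it says the series, first, only, none or still open, it means among the compounds named here.

Two compounds that share a stilbene core carrying a sulfonamide have been measured so far. Compound 1, `NS(=O)(=O)c1ccc(/C=C/c2ccc(O)c(O)c2)cc1`, carries two hydroxy groups on the ring opposite the sulfonamide. In a functional assay on OVCAR-4 cells (Homo sapiens) for inhibition (a lower number here means a stronger inhibitor of growth, a higher number a weaker inhibitor of growth), compound 1 gives 11600 nM, the lower of the two numbers recorded. Compound 2, `COc1cccc(/C=C/c2ccc(S(N)(=O)=O)cc2)c1`, carries a single methoxy group instead; in this assay compound 2 gives 25000 nM, and the gap between the two values lies beyond the usual scatter of the assay, so compound 1 is the stronger growth inhibitor of the pair.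

For the measured compounds named here, compound 3, `NS(=O)(=O)c1ccc(/C=C/c2ccc(O)cc2)cc1`, keeps only one hydroxy group. Relative to compound 1 the change is hydrogen in place of hydroxy on an aromatic carbon. Going by the values given here, no measured pair here shows the same change, so the expectation rests on the two values given. The expected step from compound 1 to compound 3 in this assay is a modest weakening, a 1.7-fold higher number from compound 1 to compound 3 (0.24 log units; within the scatter). Compound 3 is estimated to give about 20000 nM in this assay. The expected range for compound 3 runs from 7000 nM to 60000 nM.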

Compound 3, concentration for 50% growth inhibition: 36900 nM
Compound 3: the middle estimate sits 1.8-fold (0.27 log units) below what was measured, within the range that was stated.
By their numbers in this assay, from the lowest: compound 1; then compounds 2 and 3 (each within the scatter of the next).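

Replacing the hydroxy group that sits ortho to the remaining hydroxy group with hydrogen weakens growth inhibition in this assay, and the step reads as a 3.2-fold higher number from compound 1 to compound 3 (0.50 log units; beyond the scatter) and is modest in size but clearly real. The earlier compounds shown here could not show this, since compound 1 and compound 2 differ in more than one place, whereas compound 1 and compound 3 differ only at this aromatic carbon, so the loss can be assigned to this single change. The second hydroxy group therefore contributes to the activity of compound 1 in this assay, but nothing available explains how it does so, and no measurement bearing on the cause is at hand.

The compounds shown leave open whether a hydroxy group is specifically needed at this place, or whether an amine, a fluorine atom or a carboxylic acid on the same aromatic carbon would serve as well or better. Going by these compounds, it also remains open whether the remaining hydroxy group matters in the same way, since this single pair speaks only for the one position that changed.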